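The source may report more compounds than this note shows. Statements on the series, on what has been measured and on what is new or still open speak of the compounds shown alone.

Of the compounds shown here, three have been measured so far in a functional assay on the whole organism (Hindlimb, strain albino) with Mus musculus as the target, in the maximal electroshock model, with a stated time of 0.5 h; a higher number here means that more compound is needed for the effect, a lower number that less compound is needed. Compound 1 (`COc1ccc(/C=C/C(=O)Nc2nc3ccc([N+](=O)[O-])cc3s2)cc1`) gives 315 umol/kg, compound 2 (`O=C(/C=C/c1ccc(Cl)cc1)Nc1nc2ccccc2s1`) gives 367 umol/kg, and compound 3 (`COc1ccc(/C=C/C(=O)Nc2nc3ccc([N+](=O)[O-])cc3s2)cc1O`) gives 372 umol/kg. These values all lie within the usual scatter of one another, so compound 3 stands level with the other two.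

Compound 4 (`COc1ccc(/C=C/C(=O)Nc2nc3ccccc3s2)cc1O`) is compound 3 with hydrogen in place of nitro on an aromatic carbon. Among the measured compounds shown here, no measured step makes this exact change. For the measured compounds named here, the only measured step is a 1.2-fold higher number from compound 1 to compound 3 (0.07 log units; within the scatter), and it concerns a different change, hydroxy in place of hydrogen on an aromatic carbon. Compound 2 also has no nitro, and it differs from compound 3 in other places too, yet compound 2 gives 367 umol/kg, level with the compounds that carry nitro. This evidence is thin, but it points to no step beyond the scatter in this assay, in either direction. The estimated change is a 1.1-fold lower number from compound 3 to compound 4 (0.03 log units; within the scatter). For compound 4 the estimated value is 350 umol/kg, with an expected range from 180 umol/kg to 680 umol/kg.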

Compound 4, dose for half-maximal effect: 495 umol/kg
The estimate for compound 4 lay 1.4-fold (0.15 log units) below the measured number; the measured number falls inside the stated range.
By their numbers in this assay, from the lowest: compounds 1, 2, 3 and 4 (each within the scatter of the next).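

In this assay, hydrogen in place of nitro on the aromatic carbon gives a 1.3-fold higher number from compound 3 to compound 4 (0.12 log units; within the scatter), so the two compounds stand level. Among the compounds shown here, this is the first direct reading of this change at this position, on the six-membered aromatic ring of carbon only, meta to a fused ring and para to a fused ring; until now, the only hint came from compound 2, which differs from the nitro compounds in other places too. Within these two compounds, then, the nitro group can go without a step beyond the scatter, and nothing available explains why the number stays level.

From the compounds shown here alone, it remains open whether an amine or a carboxylic acid at this position would move the number beyond the scatter. Also open, going by these compounds, is whether hydrogen in place of nitro would read the same in a compound without the hydroxy group.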